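This account rests on a few compounds, and the source may have more. Where it says the series, first, only, none or still open, it means among the compounds named here.

Measured compounds:
compound 1, `Oc1ccc(-c2cc(-c3ccc(O)cc3)nc(-c3ccc(O)cc3)c2)cc1`, with 3.8%
compound 2, `Oc1ccc(-c2cc(-c3cccc(O)c3)cc(-c3ccccc3O)n2)cc1`, with 8.4%

In an assay on isolated protein for inhibition of DNA topoisomerase 1 (Homo sapiens), with a stated time of 30 min, tested at 100 uM (on this read-out lower numbers stand for less inhibition and higher numbers for more inhibition at the one concentration tested (going by the name of the read-out)), compound 1 gives 3.8%, and compound 2 gives 8.4%. On the numbers shown, compound 1 stands at the low end of the two, but the number for compound 2 falls within the usual scatter of it, so the two compounds are not distinguished by this read-out. Among the measured compounds shown here, no pair of measured compounds differs in only one place, so no single step between measured compounds is available.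

Compound 3, `Oc1ccc(-c2cc(-c3ccccc3O)cc(-c3ccc(O)cc3)n2)cc1`, has the same atoms as compound 1 joined differently: 2-hydroxyphenyl in place of 4-hydroxyphenyl on an aromatic carbon. Both measured compounds show only weak inhibition in this assay, and compound 2, which itself carries a 2-hydroxyphenyl group, gives a number within the scatter of compound 1. On that basis the step of a number 2.2 percentage points higher from compound 1 to compound 3 (within the scatter) is expected to stay within the scatter, with no clear direction. Compound 3 is therefore estimated to give 6% in this assay, in a range from 0% to 18%.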

Compound 3, a percentage reported as inhibition, at one concentration (the size of the read-out at that concentration, not a potency): 0.4%
Estimate against measurement, compound 3: 5.6 percentage points above; the measured number falls inside the stated range.
By their numbers in this assay, from the lowest: compounds 3, 1 and 2 (each within the scatter of the next).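

Placing 2-hydroxyphenyl in place of 4-hydroxyphenyl on the aromatic carbon opposite the ring nitrogen gives the only comparison among these compounds that differs in one place, and in this assay it is a number 3.4 percentage points lower from compound 1 to compound 3 (within the scatter). This single comparison shows that moving the hydroxyl group around this one phenyl ring, with the atoms otherwise unchanged, does not separate compound 1 from compound 3 on this read-out, and both compounds remain at little inhibition at the one concentration tested. No measured evidence bears on this result, so it offers no explanation for it.

What the compounds shown leave open is whether anything other than a hydroxyphenyl at this position, such as an aminophenyl group or a phenyl ring carrying a carboxylic acid, would give a number clearly apart from those of compound 1 and compound 3. They also leave open how the two 4-hydroxyphenyl groups that stay in place in this step bear on the read-out, as no single change at either of those places is available.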